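The compounds below may be only part of what the source reports. "The series", "measured", "known", "first", "only" and "open" are said of these compounds alone.

Compound 1, `Cc1nc(N2CCC(O)CC2)nc2ccc(NC(=O)C(C)(C)Oc3ccc(Cl)cc3)cc12`. Compound 2, `CCC1(O)CCN(c2nc(C)c3cc(NC(=O)COc4ccc(Cl)cc4)ccc3n2)CC1`. Compound 3, `Cc1nc(N2CCC(C)(O)CC2)nc2ccc(NC(=O)COc3ccc(Cl)cc3)cc12`.

In an assay on CHO-K1 cells for displacement of a labelled ligand from melanin-concentrating hormone receptor 1 (Homo sapiens), with a stated time of 2 h (on this read-out higher numbers stand for weaker inhibition and lower numbers for stronger inhibition), compound 2 gives 208 nM and compound 3 gives 237 nM. Compound 1 gives only a limit in this assay, > 10000 nM. Compound 3 thus holds the higher of the two numbers, with compound 2 nearest; the step of a 1.1-fold higher number from compound 2 to compound 3 (0.06 log units; within the scatter) lies within the scatter. Compound 4, `CCN1CCN(c2nc(C)c3cc(NC(=O)COc4ccc(Cl)cc4)ccc3n2)CC1`, differs from compound 3 in one place: 4-ethylpiperazin-1-yl in place of 4-hydroxy-4-methylpiperidin-1-yl on an aromatic carbon. Among the measured compounds shown here, no measured step touches this part of the structure; the single measured step concerns a different part of the molecule and was itself within the scatter. The expected step of a 1.2-fold lower number from compound 3 to compound 4 (0.07 log units; within the scatter) is therefore small in either direction, with a wide range. Compound 4 is expected to give about 200 nM, between 40 nM and 1000 nM.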

Compound 4, half-maximal inhibitory concentration: 690 nM
The estimate for compound 4 lay 3.5-fold (0.54 log units) below the measured number, within the range that was stated.
By their numbers in this assay, from the lowest: compounds 2 and 3 (each within the scatter of the next); then compound 4. At a limit, above all of these: compound 1.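

In this assay, among the compounds shown here, the earlier compounds showed only a change within the scatter at the 4-position of the piperidine, whereas exchanging the whole group on the aromatic carbon between two ring nitrogen atoms for 4-ethylpiperazin-1-yl moves the number beyond it (a 2.9-fold higher number from compound 3 to compound 4 (0.46 log units; beyond the scatter)). The same holds when 4-ethyl-4-hydroxypiperidin-1-yl leaves (a 3.3-fold higher number from compound 2 to compound 4 (0.52 log units; beyond the scatter)). Nothing at hand bears on a cause for these steps.

The compounds shown leave open how a morpholine, an unsubstituted piperidine or a 4-methylpiperazine would read at this position.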